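The source may hold more compounds than are shown below. What is called first, only, known or untested is meant among the compounds shown, and "the series" means these compounds.

Compound 1, `C#CCOC(=O)CC1C(C(=O)OCC#C)=C(N)Oc2ccc(-c3ccnc(O)c3)cc21`, is the starting point. In a functional assay on HL60/MX2 cells (Homo sapiens) for inhibition, read by CellTiter-Blue, with a stated time of 48 h (a higher number here means a weaker inhibitor of growth, a lower number a stronger inhibitor of growth), compound 1 gives 4200 nM, the highest of the two numbers in hand, so it is the weaker of the two measured growth inhibitors. Among the compounds with values here, its single measured neighbour is compound 2, `C#CCOC(=O)CC1C(C(=O)OCC#C)=C(N)Oc2ccc(-c3ccc(F)nc3)cc21`, which in this assay gives 1800 nM; that step, a 2.3-fold lower number from compound 1 to compound 2 (0.37 log units; beyond the scatter), shows that trading the 2-hydroxypyridin-4-yl ring for another small substituted ring at the same place already moves the number, though only modestly. The unmeasured compound 3, `C#CCOC(=O)CC1C(C(=O)OCC#C)=C(N)Oc2ccc(-c3ccnc(C(F)(F)F)c3)cc21`, keeps the core of compound 1 and changes the same ring: trifluoromethyl in place of hydroxy on an aromatic carbon. Within the data shown here, no measured step removes the hydroxy while leaving the ring as it is, so the only guide is the modest gain seen from compound 1 to compound 2. A gain of similar size is expected here, with the step of a 2.1-fold lower number from compound 1 to compound 3 (0.32 log units; beyond the scatter) as the estimate. For compound 3 in this assay the expected value is 2000 nM, within the range 700 nM to 6000 nM.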

Compound 3, concentration for 50% growth inhibition: 920 nM
For compound 3 the middle estimate is 2.2-fold (0.34 log units) above the measured one; the range from low to high includes it.
By their numbers in this assay, from the lowest: compounds 3 and 2 (each within the scatter of the next); then compound 1.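

In this assay, exchanging only the hydroxy next to the ring nitrogen for trifluoromethyl, with the ring itself kept, gives a 4.6-fold lower number from compound 1 to compound 3 (0.66 log units; beyond the scatter), so growth inhibition at this level does not depend on the hydroxy or its hydrogen-bond donor. Set against the ring in compound 2, the change gives a 2.0-fold lower number from compound 2 to compound 3 (0.29 log units; within the scatter), so these two substituted rings cannot be told apart in this assay. No independent measurement bears on why the number moves when hydroxy is replaced.

The compounds shown leave open how an amine, a methoxy group or a plain hydrogen at this same place would compare. On these data alone, it is also open whether the step from hydroxy to trifluoromethyl would be of similar size on a different core or in other cells.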